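The compounds below may be only part of what the source reports. "The series", "measured", "known", "first", "only" and "open" are said of these compounds alone.

Measured so far:
- compound 1 (`Cc1cc(C)c(NC(=O)c2sccc2S(=O)(=O)Nc2onc(C)c2Cl)c(C)c1`) gives 81600 nM
- compound 2 (`Cc1cc(C)c(S(N)(=O)=O)c(C)c1NC(=O)c1sccc1S(=O)(=O)Nc1onc(C)c1Cl`) gives 5590 nM

In an in vivo ADME assay on the whole organism (plasma) for pharmacokinetics, with Rattus norvegicus as the target, at a dose of 50 mg/kg by the oral route (on this read-out lower numbers stand for lower exposure and higher numbers for higher exposure at the dose given), compound 1 stands highest of the two numbers, at 81600 nM and well clear of compound 2. Next in line is compound 3 (`Cc1cc(C)c(NC(=O)c2sccc2S(=O)(=O)Nc2onc(C)c2Cl)c(Cl)c1`), with this difference: chloro in place of methyl on an aromatic carbon (2,4,6-trimethylphenyl becomes 2-chloro-4,6-dimethylphenyl). Within the data shown here, only one measured step bears on it, the large 15-fold lower number from compound 1 to compound 2 (1.16 log units; beyond the scatter) for sulfamoyl in place of hydrogen on an aromatic carbon. That step shows this read-out can move far on a single change, but it involves another kind of group, so it gives only weak guidance here. A much smaller swap of one heavy atom for another is expected to give a slight fall. The estimated step is a 1.4-fold lower number from compound 1 to compound 3 (0.13 log units; within the scatter) and may not exceed the scatter. For compound 3 the expected value is 60000 nM (estimated range 22000 nM to 150000 nM).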

Compound 3, maximal plasma concentration: 103000 nM
For compound 3 the middle estimate is 1.7-fold (0.23 log units) below the measured one, and the stated range covers the measured number.
By their numbers in this assay, from the lowest: compound 2; then compounds 1 and 3 (each within the scatter of the next).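

In this assay, chloro in place of methyl on this aromatic carbon, ortho to a large group, gives a 1.3-fold higher number from compound 1 to compound 3 (0.10 log units; within the scatter), so compound 1 and compound 3 cannot be told apart on this read-out. This position therefore accepts the swap from 2,4,6-trimethylphenyl to 2-chloro-4,6-dimethylphenyl with no step beyond the scatter, whereas the sulfamoyl change gave a 15-fold lower number from compound 1 to compound 2 (1.16 log units; beyond the scatter); a large step is thus not general to single changes on this ring. Nothing available explains why methyl and chloro read alike here.

From the compounds shown here alone, it remains open whether an amine or a carboxylic acid at this position would stay level with methyl and chloro or give a large step like sulfamoyl. The compounds shown also leave open whether the chloro swap would read the same with the sulfamoyl group present.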